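This account rests on a few compounds, and the source may have more. Where it says the series, first, only, none or still open, it means among the compounds named here.

In a functional assay on Caco-2 cells (Homo sapiens) for inhibition, read by MTT assay, with a stated time of 48 h, tested at 10 uM (on this read-out lower numbers stand for less inhibition of growth and higher numbers for more inhibition of growth at the one concentration tested), three related compounds have been measured so far. Compound 1 `Cc1cc(=O)c2c(O)c(CN(C)CC(=O)O)c(O)c([C@H]3CCN(C)C[C@H]3O)c2o1` gives 18%, compound 2 `Cc1cc(=O)c2c(O)c(CN3CCCCC3)c(O)c([C@H]3CCN(C)C[C@H]3O)c2o1` gives 22%, and compound 3 `Cc1oc2c([C@H]3CCN(C)C[C@H]3O)c(O)cc(O)c2c(=O)c1C(O)c1ccc([N+](=O)[O-])cc1` gives 5%. Compound 3 is the lowest of the three, and its gaps to both others lie beyond the scatter.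

Compound 4 `Cc1oc2c([C@H]3CCN(C)C[C@H]3O)c(O)cc(O)c2c(=O)c1C(O)c1ccc(Cl)cc1`, not yet measured, differs from compound 3 in one group: chloro in place of nitro on an aromatic carbon. The exchange sits on an aromatic carbon, para to a large group, so that 4-nitrophenyl becomes 4-chlorophenyl.

Within the data shown here, only one measured step is available, a number 4 percentage points higher from compound 1 to compound 2 (within the scatter). It lies within the scatter, but it concerns another place, a saturated chain carbon bound to an aromatic carbon, so it bears on this exchange only indirectly. Among the measured compounds shown here, no measured pair shows what a change on this aromatic ring does. The best anchor is therefore compound 3 itself, at 5%, and no step beyond the scatter is expected in this assay. The expected change is small, an estimated a number 4 percentage points higher from compound 3 to compound 4 (within the scatter). Compound 4 is estimated at 9%, with an expected range from 1% to 20%.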

Compound 4, percent growth inhibition at one concentration: 3%
Estimate against measurement, compound 4: 6 percentage points above; the range from low to high includes it.
By their numbers in this assay, from the lowest: compounds 4 and 3 (each within the scatter of the next); then compounds 1 and 2 (each within the scatter of the next).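

In this assay, among these compounds, the exchange of nitro for chloro on the aromatic carbon, para to a large group, gives a number 2 percentage points lower from compound 3 to compound 4 (within the scatter), and this is the only measured step at this place on the ring; the step among the earlier compounds concerned a saturated chain carbon. It shows that, with the rest of the structure unchanged, a group of three heavy atoms with two hydrogen-bond acceptors can give way to a single chlorine atom with none, and the growth inhibition at the one concentration tested stays within the scatter. Nothing in the information at hand explains this outcome, and it cannot be told from this one pair what the two groups have in common at this position.

From the compounds shown here alone, whether an amine, a carboxylic acid or a methoxy group at the same ring carbon would give a step beyond the scatter remains open. Also open, going by these compounds, is what the hydroxy group on the chain carbon that carries the 4-chlorophenyl ring contributes, since compounds 3 and 4 both keep it and neither is one change away from compound 1 or compound 2.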